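Lengthening the amide tether on a shared core

The source may hold more compounds than are shown below. What is called first, only, known or untested is meant among the compounds shown, and "the series" means these compounds.

Measured so far:
compound 1 `CCCCc1oc2ccccc2c1C(=O)c1ccc(OCC(N)=O)cc1` gives > 50000 nM
compound 2 `CCCCc1oc2ccccc2c1C(=O)c1ccc(OCC(=O)NC(C)C)cc1` gives > 50000 nM
compound 3 `CCCCc1oc2ccccc2c1C(=O)c1ccc(OCC(=O)Nc2ccccc2)cc1` gives > 50000 nM

In a functional assay on MDA-MB-231 cells (Homo sapiens) for antiproliferative activity, read by MTT assay, with a stated time of 24 h (a lower number here means a stronger inhibitor, a higher number a weaker inhibitor), compound 1 stands only at a limit of the assay. Compound 2 likewise reports only a limit. Compound 3 also reports only a limit. All three share (the limit of > 50000 nM in this assay, at which 3 of the 3 values shown sit), so the steps a step that the two limits leave unreadable from compound 1 to compound 2, a step that the two limits leave unreadable from compound 1 to compound 3 and a step that the two limits leave unreadable from compound 2 to compound 3 cannot be read in size or direction.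

Compound 4 `CCCCc1oc2ccccc2c1C(=O)c1ccc(OCCCC(=O)N2CCCCC2)cc1` differs from compound 1 by 2-((piperidin-1-yl)carbonyl)ethyl in place of carbamoyl on a saturated chain carbon bound to an oxygen on an aromatic ring. Among the measured compounds shown here, no measured step bears readably on this change, so no step beyond the scatter can be expected in either direction. Compound 4 is therefore estimated at 50000 nM, with a range from 15000 nM to 150000 nM, most likely again only a limit. That estimate means an expected step of a number no higher from compound 1 to compound 4 (the limit leaves the size open).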

Compound 4, half-maximal inhibitory concentration: 36000 nM
Beside the measured number, compound 4's estimate is 1.4-fold (0.14 log units) above it; the range from low to high includes it.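

Among the compounds shown here, compound 4, with 3-((piperidin-1-yl)carbonyl)propyl in place of carbamoylmethyl, is the first compound here to give a number rather than a limit in this assay: compound 4 gives 36000 nM. The steps are an at least 1.3-fold lower number from compound 1 to compound 4 (0.14 log units; that floor lies within the scatter), an at least 1.3-fold lower number from compound 2 to compound 4 (0.14 log units; that floor lies within the scatter) and an at least 1.3-fold lower number from compound 3 to compound 4 (0.14 log units; that floor lies within the scatter), so the change is not shown to exceed the usual scatter. The steps among compound 1, compound 2 and compound 3 cannot be read: the limit of > 50000 nM in this assay, at which 3 of the 4 values shown sit.

Going by these compounds, compound 4 changes the chain and the amide end together, so the part that matters remains open. A plain primary amide, a morpholine amide or a carboxylic acid on the same longer chain remains untested among the compounds shown.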